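Compound 4 and the limits of the solubility read-out

The compounds below may be only part of what the source reports. "The series", "measured", "known", "first", "only" and "open" are said of these compounds alone.

Compound 1 (`CNC(=O)c1cc(C(=O)N[C@H]2[C@@H]3C[C@H](O)C[C@@H]32)cc2c1OC[C@@]2(C)c1ccccc1`) gives the limit >= 151 ug/mL in a physicochemical assay for solubility; on this read-out higher numbers stand for higher solubility and lower numbers for lower solubility
Compound 2 (`CNC(=O)c1cc(C(=O)N[C@H]2[C@@H]3COC[C@@H]32)cc2c1OC[C@H]2c1ccccc1`) gives the limit >= 165 ug/mL in this assay
Compound 3 (`CNC(=O)c1cc(C(=O)N[C@H]2[C@@H]3COC[C@@H]32)cc2c1O[C@H](CF)[C@H]2c1ccccc1`) gives the limit >= 206 ug/mL in this assay

Compound 3 stands at a limit (>= 206 ug/mL) and not at a number. The two other values are limits as well, so the series offers no measured number to work from.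

Compound 4 (`CNC(=O)c1cc(C(=O)NC)c2c(c1)[C@H](c1ccccc1)[C@@H](CF)O2`) differs from compound 3 on an amide-type nitrogen (one carbon atom in place of a group of 6 heavy atoms (5 carbon, 1 oxygen; one three-membered non-aromatic ring of carbon only, one five-membered non-aromatic ring with 1 hetero atom), on an amide-type nitrogen) where one carbon atom, a methyl, stands in place of a group of 6 heavy atoms. Going by the values given here, the only measured step is a step that the two limits leave unreadable from compound 2 to compound 3 with fluoromethyl in place of hydrogen on a saturated ring carbon. That step does not touch the nitrogen in question, and its size cannot be read, so it gives no size to carry over.

No shift beyond the usual scatter can therefore be expected in either direction in this assay on this evidence. The expected change is a step that the limit leaves unreadable from compound 3 to compound 4 and it remains an estimate anchored on a limit. In this assay compound 4 is estimated at 210 ug/mL with an expected range from 100 ug/mL to 420 ug/mL and it may well read out as a limit again.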

Compound 4, solubility: >= 149 ug/mL
Compound 4 was reported as a limit; the forecaster's own chance of this, stated with the estimate: 65%; the middle value does not contradict the limit.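

In this assay compound 4 gives >= 149 ug/mL as a limit and not a number. Compound 3 also gives >= 206 ug/mL as a limit. Going by these compounds alone, no step between compound 3 and compound 4 can be read from these two limits. The compounds shown leave open whether replacing the larger group with methyl on the amide-type nitrogen shifts this assay at all.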